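Second methoxy on the anilino ring of compound 3

A few compounds are considered here, and "the series" means these few. Any claim that something is new, unique, unknown or untested is made for them only; others in the source may bear on it.

Compound 3 `COc1ccc(Nc2nc(SCc3ccc(C(F)(F)F)cc3)nc3ccccc23)cc1` gives 15700 nM in a functional assay on MDA-MB-231 cells (Homo sapiens) for cytotoxicity, read by MTT assay, with a stated time of 72 h (a lower number here means a stronger inhibitor, a higher number a weaker inhibitor), the lowest of the two numbers shown, with compound 1 `FC(F)(F)c1ccc(CSc2nc(Nc3ccccc3)c3ccccc3n2)cc1` nearest at 18400 nM. Compound 2 `Cc1ccc(Nc2nc(SCc3ccc(C(F)(F)F)cc3)nc3ccccc23)cc1` reaches the limit > 50000 nM in this assay. Compound 4 `COc1ccc(Nc2nc(SCc3ccc(C(F)(F)F)cc3)nc3ccccc23)cc1OC` differs from compound 3 by methoxy in place of hydrogen on an aromatic carbon. Going by the values given here, the one directly comparable step is a 1.2-fold lower number from compound 1 to compound 3 (0.07 log units; within the scatter), a methoxy in place of hydrogen that left the number essentially unchanged; an at least 2.7-fold higher number from compound 1 to compound 2 (0.43 log units; beyond the scatter) and an at least 3.1-fold lower number from compound 2 to compound 3 (0.50 log units; beyond the scatter) concern a methyl and bear less on a further methoxy. Among the compounds with values here, no measured step points to a change beyond the scatter in this assay. Compound 4 is therefore expected to show a 1.0-fold lower number from compound 3 to compound 4 (0.02 log units; within the scatter). The estimate for compound 4 is 15000 nM, within 7000 nM to 35000 nM.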

Compound 4, half-maximal inhibitory concentration: 18900 nM
Compound 4: middle estimate off by 1.3-fold (0.10 log units), on the low side, within the range that was stated.
By their numbers in this assay, from the lowest: compounds 3, 1 and 4 (each within the scatter of the next). At a limit, above all of these: compound 2.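

In this assay the second methoxy, ortho to a methoxy group, gives a 1.2-fold higher number from compound 3 to compound 4 (0.08 log units; within the scatter) and so shows no readable difference from the single methoxy. The 3,4-dimethoxyphenyl also reads alike with plain phenyl, with a 1.0-fold higher number from compound 1 to compound 4 (0.01 log units; within the scatter) on record, so neither one nor two methoxy groups separate from the compound without a substituent on this ring. Only an at least 2.6-fold lower number from compound 2 to compound 4 (0.42 log units; beyond the scatter) lies beyond the scatter, and that step starts from a limit: the limit of > 50000 nM in this assay, at which 1 of the 4 values shown sits.

As far as these compounds go, whether an amine or a hydroxy group on this carbon would depart from these values stays open. So does whether a longer chain in place of methoxy would.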